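Chloroalkyl Amide Exchanged for a Cyclopentylmethyl Urea

The source may report more compounds than this note shows. Statements on the series, on what has been measured and on what is new or still open speak of the compounds shown alone.

Measured compounds:
compound 1 `CCCC(=O)Nc1ccc(S(=O)(=O)Oc2ccccc2C(C)C)cc1`: 6600 nM
compound 2 `CC(C)c1ccccc1OS(=O)(=O)c1ccc(NC(=O)CCCCl)cc1`: 5200 nM

Of the compounds shown here, two have been measured in a functional assay on MCF7 cells (Homo sapiens) for antiproliferative activity, read by sulforhodamine B assay, with a stated time of 48 h; a higher number here means a weaker inhibitor, a lower number a stronger inhibitor. Compound 1 gives 6600 nM and compound 2 gives 5200 nM. Compound 2 stands at the lower end of these two numbers, but the step of a 1.3-fold lower number from compound 1 to compound 2 (0.10 log units; within the scatter) lies within the scatter, so the two cannot be told apart. Compound 3 `CC(C)c1ccccc1OS(=O)(=O)c1ccc(NC(=O)NCC2CCCC2)cc1` has not yet been measured. It differs from compound 2 in one place: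

(cyclopentylmethyl)amino in place of 3-chloropropyl on a carbonyl carbon

For the measured compounds named here, the only measured step, a 1.3-fold lower number from compound 1 to compound 2 (0.10 log units; within the scatter), altered the chain beyond the carbonyl and left the carbonyl and its amide-type nitrogen in place, so it does not bear on this exchange; no measured pair shows how this assay answers the change from a (3-chloropropyl)carbonyl to a (cyclopentylmethyl)carbamoyl. The expectation for compound 3 therefore rests on staying close to the measured numbers, with a step of a 1.0-fold lower number from compound 2 to compound 3 (0.02 log units; within the scatter) and a wide range. The value of compound 3 is estimated at 5000 nM, from 1500 nM to 16000 nM.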

Compound 3, half-maximal inhibitory concentration: 7100 nM
Compound 3: the middle estimate sits 1.4-fold (0.15 log units) below what was measured; low and high end bracket the measured number.
By their numbers in this assay, from the lowest: compounds 2, 1 and 3 (each within the scatter of the next).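

In this assay, placing (cyclopentylmethyl)amino on the carbonyl carbon in place of 3-chloropropyl gives a 1.4-fold higher number from compound 2 to compound 3 (0.14 log units; within the scatter) and, in place of propyl, a 1.1-fold higher number from compound 1 to compound 3 (0.03 log units; within the scatter) as the second reading. Both steps lie within the scatter, so a group carrying a five-membered non-aromatic ring and a hydrogen-bond donor cannot be told apart from either open chain at this position. The exchange of the amide for the urea thus leaves all three compounds indistinguishable here, and no available data speak to why.

Still open, from the compounds shown here alone, is whether any group on this carbonyl carbon can move the number beyond the scatter. A benzylamino, a morpholine or a chain ending in a carboxylic acid could test that, as could a cyclohexylmethylamino, which would show whether ring size matters.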